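One Less Bromine in a Paw-Swelling Series

This account rests on a few compounds, and the source may have more. Where it says the series, first, only, none or still open, it means among the compounds named here.

Compound 1 `O=c1cc(CNc2nc(-c3cc4cc(Br)cc(Br)c4oc3=O)cs2)c2cc(Cl)ccc2[nH]1`, compound 2 `Cc1cccc2c(CNc3nc(-c4cc5cc(Br)ccc5oc4=O)cs3)cc(=O)[nH]c12` and compound 3 `Cc1cccc2c(CNc3nc(-c4cc5cc(Br)cc(Br)c5oc4=O)cs3)cc(=O)[nH]c12` were tested in a functional assay on the whole organism for inhibition, with Rattus norvegicus as the target, read by paw edema, in the formalin test, with a stated time of 12 h, at a dose of 100 mg/kg by the intraperitoneal route; a lower number here means less inhibition, a higher number more inhibition at the dose given (going by the name of the read-out). In this assay compound 1 gives 14.4%, compound 2 gives 24.1% and compound 3 gives 16.7%. The difference between the core of compound 1 and the core of compound 3 is not broken down here. Compound 3 and compound 2 differ in one place, (hydrogen in place of bromo on an aromatic carbon), and this gave a number 7.4 percentage points higher from compound 3 to compound 2 (within the scatter). Compound 4 `O=c1cc(CNc2nc(-c3cc4cc(Br)ccc4oc3=O)cs2)c2cc(Cl)ccc2[nH]1`, not yet measured, arises from compound 1 by the same change, (hydrogen in place of bromo on an aromatic carbon), at a place described in the same words. The expected step of a number 7.6 percentage points higher from compound 1 to compound 4 (within the scatter) rests on the measured step of a number 7.4 percentage points higher from compound 3 to compound 2 (within the scatter). Compound 4 is therefore estimated at 22% in this assay. For compound 4 the expected range runs from 8% to 36%.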

Compound 4, a percentage reported as inhibition, in the whole organism at one dose (the size of the read-out at that dose, not a potency): 15.6%
The estimate for compound 4 lay 6.4 percentage points above the measured number; low and high end bracket the measured number.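

Replacing bromo with hydrogen on the core of compound 1 gave a number 1.2 percentage points higher from compound 1 to compound 4 (within the scatter). Set beside the same swap on the other core, the two steps cannot be told apart: the same change on two cores in this assay, a number 7.4 percentage points higher (within the scatter) from compound 3 to compound 2 and a number 1.2 percentage points higher (within the scatter) from compound 1 to compound 4, 6.2 percentage points apart, within the scatter of two such steps

This fits the change carrying over between these two cores, but neither step stands clear of the scatter, so it does not show that swapping bromo for hydrogen raises inhibition on either core. The compounds shown leave open what a different group in that place, such as an amine or a carboxylic acid, would do in this assay. On these data alone, each number also comes from a single dose, so how potency compares across the compounds remains open.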